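Fluoro to Chloro on an Aromatic Ring: Compound 1 to Compound 4

The source may hold more compounds than are shown below. What is called first, only, known or untested is meant among the compounds shown, and "the series" means these compounds.

Three compounds have been measured in a functional assay on HepG2 cells (Homo sapiens) for inhibition, read by MTT assay, with a stated time of 72 h; a higher number here means a weaker inhibitor, a lower number a stronger inhibitor:

Compound 1, `Cc1nc(N(C)C(=O)NC(=O)c2c(F)cccc2F)sc1C(=O)N/N=C/c1ccccc1F`: > 100 ug/mL (a limit of the assay, not a number)
Compound 2, `CN(C(=O)NC(=O)c1cccc(C(F)(F)F)c1)c1nc(C(F)(F)F)c(C(=O)N/N=C/c2ccccc2C(F)(F)F)s1`: 10.4 ug/mL
Compound 3, `CN(C(=O)NC(=O)c1ccccc1F)c1nc(C(F)(F)F)c(C(=O)N/N=C/c2cccc(C(F)(F)F)c2)s1`: 20.3 ug/mL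

Compound 1 stands apart from the other two on the numbers shown. For compound 1 this assay reports only a limit, (the limit of > 100 ug/mL in this assay, at which 1 of the 3 values shown sits), so no number is known for it. Compound 2 and compound 3 both give numbers, and the two of them lie within the usual scatter of each other, so neither can be called the stronger one. For the measured compounds named here, since compound 1 has only a limit, no step between any two of the measured compounds can be sized.

Compound 4, `Cc1nc(N(C)C(=O)NC(=O)c2c(F)cccc2F)sc1C(=O)N/N=C/c1ccccc1Cl`, has not yet been measured. It differs from compound 1 in one place: chloro in place of fluoro on an aromatic carbon. The rest of the structure is the shared core of compound 1, unchanged.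

Going by the values given here, with no measured step to lean on, the expectation for this change is a small one, no larger than the scatter, in either direction. Compound 4 is therefore expected to sit at 120 ug/mL, within the range 40 ug/mL to 300 ug/mL, which means a step from compound 1 of about a step that the limit leaves unreadable from compound 1 to compound 4, and most likely the assay will again report only a limit.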

Compound 4, half-maximal inhibitory concentration: > 100 ug/mL
Compound 4: no number, only a limit; the forecaster's own chance of this, stated with the estimate: 70%; the middle value lies beyond the limit too.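

No step can be read from compound 1 to compound 4, since each gives only a limit of the assay and no number: the limit of > 100 ug/mL in this assay, at which 2 of the 4 values shown sit.

The compounds shown leave open whether chloro or fluoro at this place gives the stronger inhibitor in this assay and how far compound 1 and compound 4 actually lie apart.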